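Aryl thioether enones in the DU-145 growth assay

The source may report more compounds than this note shows. Statements on the series, on what has been measured and on what is new or still open speak of the compounds shown alone.

Measured so far:
compound 1 `Cc1ccsc1/C=C(/SCc1ccc(Cl)cc1)C(=O)c1ccc(Br)cc1`: 25000 nM
compound 2 `CC(=O)c1ccc(/C=C(/Sc2ccc(C)cc2)C(=O)c2ccc(Br)cc2)cc1`: 50000 nM
compound 3 `O=C(/C(=C\c1c(O)cc(O)cc1O)Sc1ccccc1Br)c1ccc(Br)cc1`: > 100000 nM

In a functional assay on DU-145 cells (Homo sapiens) for inhibition, read by trypan blue exclusion, with a stated time of 96 h (on this read-out higher numbers stand for weaker inhibition of growth and lower numbers for stronger inhibition of growth), compound 2 gives 50000 nM. Of the numbers shown it is the largest, but the only other number, that of compound 1 in this assay at 25000 nM, lies within the usual scatter of it, so the two cannot be told apart. Compound 3 in this assay reaches only a limit of the assay, > 100000 nM; this is the limit noted as the limit of > 100000 nM in this assay, at which 1 of the 3 values shown sits, and not a number.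

Compound 4 `Cc1ccc(S/C(=C/c2sccc2C)C(=O)c2ccc(Br)cc2)cc1` has not yet been measured. It differs from compound 2 in one place: 3-methylthiophen-2-yl in place of 4-acetylphenyl on a double-bonded chain carbon bound to a double-bonded chain carbon. For the measured compounds named here, the group that enters is the one already carried by compound 1, while the aryl thioether of compound 2 is kept. Since compound 1 and compound 2 in this assay sit within the scatter of each other, no step beyond the scatter is expected from compound 2 to compound 4 in this assay; the estimated step is a 1.4-fold lower number from compound 2 to compound 4 (0.15 log units; within the scatter). Compound 4 is therefore expected to give about 35000 nM in this assay, with a likely range from 12000 nM to 100000 nM.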

Compound 4, concentration for 50% growth inhibition: 50000 nM
Compound 4: the middle estimate sits 1.4-fold (0.15 log units) below what was measured; low and high end bracket the measured number.
By their numbers in this assay, from the lowest: compounds 1, 2 and 4 (each within the scatter of the next). At a limit, above all of these: compound 3.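

In this assay, 3-methylthiophen-2-yl in place of 4-acetylphenyl on a double-bonded chain carbon bound to a double-bonded chain carbon gives no change at the digits printed from compound 2 to compound 4 (within the scatter). For the compounds shown here, this is the first reading at this position with the aryl thioether held constant, and it shows that replacing a six-membered carbon ring carrying an acetyl group with a smaller five-membered ring with one hetero atom does not separate the two compounds. On the sulfur, with 3-methylthiophen-2-yl held constant, 4-methylphenyl in place of 4-chlorobenzyl gives a 2.0-fold higher number from compound 1 to compound 4 (0.30 log units; within the scatter), so these two one-place steps leave compounds 1, 2 and 4 indistinguishable in this assay.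

From the compounds shown here alone, whether either position can move the number beyond the scatter stays open, including what an amine or a carboxylic acid would do in place of 3-methylthiophen-2-yl, or a longer chain on the sulfur. Compound 3 stands at a limit of the assay and not at a number, and steps from it to the other compounds cannot be read: the limit of > 100000 nM in this assay, at which 1 of the 4 values shown sits.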